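A few compounds are considered here, and "the series" means these few. Any claim that something is new, unique, unknown or untested is made for them only; others in the source may bear on it.

- Compound 1 `CCNc1c(C)c(C)c2c(c1C)CC(C)(C)O2`: 38.9 mg/kg
- Compound 2 `Cc1c(C)c2c(c(C)c1NS(C)(=O)=O)CC(C)(C)O2`: > 100 mg/kg

In a functional assay on the whole organism with Mus musculus as the target (a lower number here means that less compound is needed, a higher number that more compound is needed for the effect), compound 1 gives 38.9 mg/kg. For compound 2, the entry > 100 mg/kg is a limit of the assay and not a number.

Compound 3 `Cc1ccc(S(=O)(=O)Nc2c(C)c(C)c3c(c2C)CC(C)(C)O3)cc1` keeps the sulfonyl group of compound 2 and changes what it carries: 4-methylphenyl in place of methyl on a sulfonyl sulfur. For the measured compounds named here, the only measured step is an at least 2.5-fold higher number from compound 1 to compound 2 (0.41 log units; beyond the scatter), which lies beyond the scatter. Going by the values given here, no measured step shows a change on the sulfonyl sulfur, so its size must be judged indirectly. The sulfonyl group arrived with that single rise, and it stays in place, so no step beyond the scatter is expected in this assay, and the direction is open. The expected step is a step that the limit leaves unreadable from compound 2 to compound 3. For compound 3 the estimate is 120 mg/kg, with an expected range from 50 mg/kg to 300 mg/kg. A reading that gives only a limit is also expected to be likely.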

Compound 3, dose for 50% inhibition: > 100 mg/kg
Compound 3: no number, only a limit; the forecaster's own chance of this, stated with the estimate: 70%; the middle value is on the limit's open side.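

The step from compound 2 to compound 3 cannot be read, because both compounds give only the same limit and not a number: the limit of > 100 mg/kg in this assay, at which 2 of the 3 values shown sit.

The compounds shown leave open whether 4-methylphenyl or methyl on a sulfonyl sulfur needs less compound for the effect.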